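Cytotoxicity notes on the step from compound 2 to compound 3

The compounds below may be only part of what the source reports. "The series", "measured", "known", "first", "only" and "open" are said of these compounds alone.

Measured so far:
Compound 1 `C=C[C@@](C)(/C=C/c1ccc(O)cc1)CC/C=C(C)/C=N/N` in an ADME assay on HEK293 cells (Homo sapiens) for cytotoxicity, with a stated time of 72 h (on this read-out higher numbers stand for an effect only at larger amounts of compound and lower numbers for an effect already at smaller amounts), gives > 36600 nM, a limit of the assay and not a number.
Compound 2 `C=C[C@@](C)(/C=C/c1ccc(O)c(/C=C/C(=O)c2ccccc2)c1)CCC=C(C)C` in this assay gives > 7410 nM, likewise a limit of the assay.

Compound 2 thus stands at the limit of > 7410 nM in this assay, at which 1 of the 2 values shown sits, and no number places it. Compound 1 sits at the limit of > 36600 nM in this assay, at which 1 of the 2 values shown sits, so the two measured values are limits only, and nothing in them separates one compound from the other. For the measured compounds named here, no step between measured compounds is at hand.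

Compound 3 `C=C[C@@](C)(/C=C/c1ccc(O)c(/C=C/C(=O)OCc2ccccc2)c1)CCC=C(C)C` differs from compound 2 by benzyloxy in place of phenyl on a carbonyl carbon. With both measured values at limits, the step in this assay is expected to be none beyond the scatter, and compound 3 is expected most likely to come back as a limit again. The estimate for compound 3 in this assay is 20000 nM, between 7000 nM and 60000 nM, which means an expected step that the limit leaves unreadable from compound 2 to compound 3.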

Compound 3, half-maximal effective concentration: > 36600 nM
Compound 3 was reported as a limit; the forecaster's own chance of this, stated with the estimate: 75%; middle value at least 1.8-fold (0.26 log units) away from the limit.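

In this assay compound 2 gives > 7410 nM, a limit and not a number. Compound 3 gives > 36600 nM, also a limit, so no step can be read for this pair. Left open is whether benzyloxy in place of phenyl on a carbonyl carbon shifts cytotoxicity at all.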